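The source may report more compounds than this note shows. Statements on the series, on what has been measured and on what is new or still open speak of the compounds shown alone.

In an ADME assay (liver) for metabolic stability, with Liver microsome (Homo sapiens) as the target, read by LC-MS, using microsomes, with a stated time of 30 min, tested at 4 uM (on this read-out lower numbers stand for a less stable compound and higher numbers for a more stable compound), compound 1 `Cc1nc(N2CCN(C)CC2)c2nc(-c3cccc(Cl)c3)n(C3CCOCC3)c2n1` gives 25% and compound 2 `COc1ccccc1-c1nc2c(N3CCN(C)CC3)nc(C)nc2n1C1CCOCC1` gives 22%, so compound 2 stands level with compound 1 within the scatter. Compound 3 `COc1cccc(-c2nc3c(N4CCN(C)CC4)nc(C)nc3n2C2CCOCC2)c1` differs from compound 2 by 3-methoxyphenyl in place of 2-methoxyphenyl on an aromatic carbon, with 3-methoxyphenyl in place of 2-methoxyphenyl on an aromatic carbon. Among the measured compounds shown here, the only measured step bearing on this is a number 3 percentage points lower from compound 1 to compound 2 (within the scatter), which changed the group on that same carbon. No shift beyond the scatter is therefore expected, and the estimated change is a number 1 percentage points higher from compound 2 to compound 3 (within the scatter). Compound 3 is expected to give 23%, within an estimated range of 12% to 36%.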

Compound 3, percent of the compound remaining: 40%
Compound 3: the middle estimate sits 17 percentage points below what was measured; measured number above the stated range.
By their numbers in this assay, from the lowest: compounds 2 and 1 (each within the scatter of the next); then compound 3.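

In this assay, this carbon proves sensitive to where the methoxy sits on the phenyl group: 3-methoxyphenyl in place of 2-methoxyphenyl gives a number 18 percentage points higher from compound 2 to compound 3 (beyond the scatter), a shift that the earlier step at this carbon did not show. With the group in the same place on the phenyl ring, methoxy in place of chloro gives a number 15 percentage points higher from compound 1 to compound 3 (beyond the scatter), so the group itself also matters here. Nothing available explains either step.

The compounds shown leave open whether an amine or a carboxylic acid in place of the methoxy of compound 3 would keep this number. They also leave open whether the gain would survive a longer chain in place of the oxan-4-yl group.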